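Dichlorophenyl in Place of Methoxyphenyl: an Expected Potency

A few compounds are considered here, and "the series" means these few. Any claim that something is new, unique, unknown or untested is made for them only; others in the source may bear on it.

Measured compounds:
compound 1 `Nc1ccccc1NC(=O)c1ccc(CNC(=O)c2n[nH]cc2NC(=O)c2ccccc2)cc1`: 1590 nM
compound 2 `COc1ccccc1C(=O)Nc1c[nH]nc1C(=O)NCc1ccc(C(=O)Nc2ccccc2N)cc1`: 2660 nM

In a functional assay on A-375 cells (Homo sapiens) for inhibition, read by CCK-8 assay, with a stated time of 72 h (a lower number here means a stronger inhibitor, a higher number a weaker inhibitor), compound 2 has the higher of the two numbers, yet its gap to compound 1, a 1.7-fold higher number from compound 1 to compound 2 (0.22 log units; within the scatter), lies within the scatter. Compound 3 `Nc1ccccc1NC(=O)c1ccc(CNC(=O)c2n[nH]cc2NC(=O)c2c(Cl)cccc2Cl)cc1` differs from compound 2 in one place: 2,6-dichlorophenyl in place of 2-methoxyphenyl on a carbonyl carbon. Going by the values given here, no measured step involves a 2,6-dichlorophenyl group; the only step available, a 1.7-fold higher number from compound 1 to compound 2 (0.22 log units; within the scatter), exchanged a hydrogen for a methoxy and stayed within the scatter, so in this assay no step beyond the scatter is expected. Compound 3 is therefore estimated at 2000 nM, between 700 nM and 6000 nM, an expected step of a 1.3-fold lower number from compound 2 to compound 3 (0.12 log units; within the scatter).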

Compound 3, half-maximal inhibitory concentration: 1200 nM
For compound 3 the middle estimate is 1.7-fold (0.22 log units) above the measured one; the measured number falls inside the stated range.
By their numbers in this assay, from the lowest: compounds 3, 1 and 2 (each within the scatter of the next, the first and the last beyond it).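

In this assay, going by these compounds alone, the change to 2,6-dichlorophenyl from 2-methoxyphenyl on a carbonyl carbon gives a 2.2-fold lower number from compound 2 to compound 3 (0.35 log units; beyond the scatter) as the first step here beyond the scatter, though a modest one. Set against plain phenyl, the same group gives a 1.3-fold lower number from compound 1 to compound 3 (0.12 log units; within the scatter) and so cannot be told apart from it, which means this position has shown one small difference and no clear gain over phenyl. Still open, going by these compounds, is whether a group of another kind on this carbonyl carbon, such as an amine or a carboxylic acid, would move the number further. Nothing available explains the step seen here.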